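Swapping Bromo for Carboxyethenyl: Cytotoxicity Outlook

This account rests on a few compounds, and the source may have more. Where it says the series, first, only, none or still open, it means among the compounds named here.

Compound 1 `Cc1cc(C#N)cc(C)c1Oc1ccc(N)c(Nc2ccc(C#N)cc2)n1`: 8980 nM
Compound 2 `Cc1cc(Br)cc(C)c1Oc1ccc([N+](=O)[O-])c(Nc2ccc(C#N)cc2)n1`: > 45600 nM

Of the compounds shown here, two have been tested in an ADME assay on TZM cells (Homo sapiens) for cytotoxicity, read by XTT assay, with a stated time of 4 days; a higher number here means that more compound is tolerated, a lower number that less compound is tolerated. Compound 1 gives 8980 nM. For compound 2 the assay returns only a limit, > 45600 nM, so no number is known for it. Compound 2 thus sits at the limit of > 45600 nM in this assay, at which 1 of the 2 values shown sits.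

Compound 3 `Cc1cc(/C=C/C(=O)O)cc(C)c1Oc1ccc([N+](=O)[O-])c(Nc2ccc(C#N)cc2)n1` is the next compound, not yet measured in this assay. It differs from compound 2 in one place: 2-carboxyethenyl in place of bromo on an aromatic carbon.

Going by the values given here, no step between two measured compounds is available, so the size of this change cannot be read from the data. The step from compound 2 to compound 3 is expected to be a number no higher from compound 2 to compound 3 (the limit leaves the size open), none beyond the scatter, since compound 2 already rests at the limit of > 45600 nM in this assay, at which 1 of the 2 values shown sits. Compound 3 is expected at 45600 nM, with a range from 20000 nM to 100000 nM, and the assay will most likely again report only a limit.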

Compound 3, half-maximal cytotoxic concentration: 27800 nM
Compound 3: the middle estimate sits 1.6-fold (0.21 log units) above what was measured; the measured number falls inside the stated range.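

At this position, meta to two methyl groups and para to a large group, the enlarged substituent brings a measured number: in this assay compound 3 gives 27800 nM. Putting 2-carboxyethenyl in place of bromo, with its five heavy atoms, one hydrogen-bond donor and one hydrogen-bond acceptor, is recorded as an at least 1.6-fold lower number from compound 2 to compound 3 (0.21 log units; that floor lies within the scatter). The true size of this step cannot be read, because compound 2 carries only a limit: the limit of > 45600 nM in this assay, at which 1 of the 3 values shown sits.

The compounds shown leave open whether the number in this assay follows the carboxylic acid itself or the double bond that carries it. A methyl ester, an amide or a saturated propanoic acid chain at this position could separate those two parts.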